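A few compounds are considered here, and "the series" means these few. Any claim that something is new, unique, unknown or untested is made for them only; others in the source may bear on it.

Working notes on the series

All three compounds share one core. Compound 1 is `CNC(=O)c1cc(Oc2ccc3nc(Nc4cccc(Cl)c4)ncc3c2)ccn1` and compound 2 is `CNC(=O)c1cc(Oc2ccc3nc(Nc4cccc(C(F)(F)F)c4)ncc3c2)ccn1`. In a physicochemical assay for solubility, at pH 7 (on this read-out higher numbers stand for higher solubility and lower numbers for lower solubility), compound 1 gives < 1000 nM, which is a limit of the assay and not a number. In this assay compound 2 gives < 1000 nM, again a limit and not a number. Between them lies a step that the two limits leave unreadable from compound 1 to compound 2, so the change from chloro to trifluoromethyl cannot be sized from these two results. Compound 2 thus stands at the limit in this assay, with no number of its own; the only point that can be set down is the limit of < 1000 nM in this assay, at which 2 of the 2 values shown sit.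

Compound 3 is `CNC(=O)c1cc(Oc2ccc3nc(Nc4cccc(OC(F)(F)F)c4)ncc3c2)ccn1`. It differs from compound 2 by trifluoromethoxy in place of trifluoromethyl on an aromatic carbon. For the measured compounds named here, the single measured step, a step that the two limits leave unreadable from compound 1 to compound 2, touches the same position of the same ring, but its size is unreadable, so it gives no measure of what a change at this position does in this assay. For compound 3 the expectation is therefore a value still at or near the limit, with no step beyond the scatter foreseen. The expected step is a step that the limit leaves unreadable from compound 2 to compound 3. The estimate for compound 3 in this assay is 500 nM, with a range from 100 nM to 2500 nM.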

Compound 3, solubility: < 1000 nM
Compound 3 ended at the assay's limit; the forecaster's own chance of this, stated with the estimate: 70%; the middle value lies beyond the limit too.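

No step among compound 1, compound 2 and compound 3 can be read in this assay, as all three results are limits and not numbers: the limit of < 1000 nM in this assay, at which 3 of the 3 values shown sit.

The compounds shown leave open where the true values of these three compounds lie, and whether chloro, trifluoromethyl and trifluoromethoxy differ at all on this read-out.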